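Clearance Outlook for a Chlorofluorophenoxy Analogue

The source may report more compounds than this note shows. Statements on the series, on what has been measured and on what is new or still open speak of the compounds shown alone.

Measured compounds:
compound 1 `c1ccc(OCC2[C@H]3CN(Cc4nc5ccccc5n4C4CC4)C[C@@H]23)cc1`: "not determined" (no result reported)
compound 2 `Cn1c(CN2C[C@@H]3C(COc4cc(F)ccc4F)[C@@H]3C2)nc2ccccc21`: > 18.7 mL/min/kg

In an in vitro ADME assay on microsomes from liver (Homo sapiens) for metabolic stability, tested at 1 uM (a lower number here means slower removal, a higher number faster removal of the compound), compound 1 gives "not determined" (no result reported). In this assay, going by the values given here, compound 2 gives > 18.7 mL/min/kg, which is a limit of the assay and not a number, the one value sitting at the limit of > 18.7 mL/min/kg in this assay, at which 1 of the 2 values shown sits. Compound 3 `Cn1c(CN2C[C@@H]3C(COc4ccc(Cl)cc4F)[C@@H]3C2)nc2ccccc21` differs from compound 2 by 4-chloro-2-fluorophenyl in place of 2,5-difluorophenyl on an oxygen on a saturated carbon. Among the compounds with values here, no step between measured compounds is known, so the expectation rests on compound 2 alone: the step that the limit leaves unreadable from compound 2 to compound 3 is expected to be none beyond the scatter. Compound 3 is therefore estimated at 25 mL/min/kg, with a range from 12 mL/min/kg to 55 mL/min/kg.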

Compound 3, clearance: 6.9 mL/min/kg
For compound 3 the middle estimate is 3.6-fold (0.56 log units) above the measured one; measured number outside the range, below it.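

In this assay, going by these compounds alone, 4-chloro-2-fluorophenyl in place of 2,5-difluorophenyl on an oxygen on a saturated carbon gives an at least 2.7-fold lower number from compound 2 to compound 3 (0.43 log units; beyond the scatter), which shows that the aryl group at this place can shift clearance beyond the scatter, something the earlier compounds could not show. The full size of this step stays unread, since compound 2 carries a limit of the assay and not a number: the limit of > 18.7 mL/min/kg in this assay, at which 1 of the 3 values shown sits.

The compounds shown leave open whether the step goes with the chlorine that enters or the fluorine that leaves. From the compounds shown here alone, how a nitrile or a methoxy group at this place would read also remains open.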